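A Methyl on the Ring Amine: Compound 1 to Compound 3

This account rests on a few compounds, and the source may have more. Where it says the series, first, only, none or still open, it means among the compounds named here.

Compound 1 `O=S(=O)(c1cccc2ccccc12)c1cccc2oc(N3CCNCC3)nc12` was tested in a functional assay on HeLa cells for antagonist activity at 5-hydroxytryptamine receptor 6 (Homo sapiens), read by cAMP accumulation and immunoassay, with a stated time of 10 min (on this read-out lower numbers stand for stronger inhibition and higher numbers for weaker inhibition), where compound 1 gave 96 nM. Within the data shown here, the only other measured compound, compound 2 `O=S(=O)(c1cccc2ccccc12)c1cccc2nc(N3CCNCC3)oc12`, gave 77 nM in this assay. On the numbers shown, compound 1 carries the higher of the two values, but the gap to compound 2 lies within the scatter, so the two compounds cannot be separated on this read-out.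

Compound 3 `CN1CCN(c2nc3c(S(=O)(=O)c4cccc5ccccc45)cccc3o2)CC1` has not yet been measured. It differs from compound 1 by methyl in place of hydrogen on an amine nitrogen in a ring, or piperazin-1-yl becoming 4-methylpiperazin-1-yl. Among the measured compounds shown here, no measured pair shows this change, so its size cannot be read off; it is expected to be a small step in this assay, if anything toward a somewhat higher number, and not clearly beyond the scatter.

Compound 3 is therefore estimated to give 130 nM in this assay, with a range from 45 nM to 400 nM. The expected step of a 1.4-fold higher number from compound 1 to compound 3 (0.13 log units; within the scatter) is thus a modest one, within the scatter.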

Compound 3, half-maximal inhibitory concentration: 105 nM
For compound 3 the middle estimate is 1.2-fold (0.09 log units) above the measured one, within the range that was stated.
By their numbers in this assay, from the lowest: compounds 2, 1 and 3 (each within the scatter of the next).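

Placing methyl in place of hydrogen on an amine nitrogen in a ring, which turns piperazin-1-yl into 4-methylpiperazin-1-yl, gives in this assay a step of a 1.1-fold higher number from compound 1 to compound 3 (0.04 log units; within the scatter) and provides the first direct reading of a change at this position. The earlier compounds shown here could not show this, as they offered no pair differing only on this ring nitrogen; now compound 1, with its hydrogen there, and compound 3, with its methyl, cannot be separated on this read-out, so in this pair the hydrogen on that nitrogen is not needed to keep the value within the scatter. Nothing in the data shown offers an explanation for this result.

What the compounds shown leave open is how far this tolerance extends, since a single methyl says little about what ethyl, a longer chain, an acetyl group or a carboxylic acid on the same nitrogen would do in this read-out. As far as these compounds go, it also remains open whether the same methyl would give a similarly small step on the core of compound 2.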